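This account rests on a few compounds, and the source may have more. Where it says the series, first, only, none or still open, it means among the compounds named here.

Of the compounds shown here, three of the shared core have been measured in an assay on HL-60 cells for inhibition of glutathione S-transferase P (Homo sapiens), read by spectrophotometry, tested at 20 uM; a higher number here means more inhibition at the concentration tested (going by the name of the read-out), a lower number less inhibition. Compound 1 `Cc1ccc2c(c1)C(=O)/C(=C/c1ccccc1)CN2CC(=O)O` gives 4.23%; compound 2 `Cc1ccc2c(c1)C(=O)/C(=C/c1ccc(Br)cc1)CN2CC(=O)O` gives 28.2%; compound 3 `Cc1ccc2c(c1)C(=O)/C(=C/c1ccc(Cl)cc1)CN2CC(=O)O` gives 20.7%, the second highest of the three, reached by a number 16.5 percentage points higher from compound 1 to compound 3 (beyond the scatter) and by a number 7.5 percentage points lower from compound 2 to compound 3 (within the scatter). Compound 4 `Cc1ccc2c(c1)C(=O)/C(=C/c1ccc(F)cc1)CN2CC(=O)O` is not yet measured; it differs from compound 3 by fluoro in place of chloro on an aromatic carbon. The step bearing most directly on it is a number 7.5 percentage points lower from compound 2 to compound 3 (within the scatter), which stayed within the scatter; the step of a number 16.5 percentage points higher from compound 1 to compound 3 (beyond the scatter) shows how far the numbers move between hydrogen and chloro at that position. A small step toward the number of compound 1, within the scatter or just beyond it, is expected in this assay. Compound 4 is therefore estimated at 13% (3% to 25%), meaning a number 7.7 percentage points lower from compound 3 to compound 4 (within the scatter).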

Compound 4, a percentage reported as inhibition, at one concentration (the size of the read-out at that concentration, not a potency): 16.1%
Compound 4: the middle estimate sits 3.1 percentage points below what was measured, and the stated range covers the measured number.
By their numbers in this assay, from the lowest: compound 1; then compounds 4, 3 and 2 (each within the scatter of the next, the first and the last beyond it).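

In this assay fluoro also stands clear of hydrogen at this position, with a number 11.9 percentage points higher from compound 1 to compound 4 (beyond the scatter) as the step, so all three halogens shown share the lift over compound 1. Fluoro and chloro stay unresolved, with a number 4.6 percentage points lower from compound 3 to compound 4 (within the scatter) here, while a number 12.1 percentage points lower from compound 2 to compound 4 (beyond the scatter) separates fluoro from bromo, which the chloro and bromo pair did not do. No evidence on hand bears on these steps. As far as these compounds go, whether a group other than a halogen at this position, such as methoxy, nitrile or an amine, would keep that lift remains open.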